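Chain-end ester: an estimate from three measured compounds

This account rests on a few compounds, and the source may have more. Where it says the series, first, only, none or still open, it means among the compounds named here.

Compound 1 `COCCCCCCCCCCCCCCC/C=C1\CC(CO)(COC(=O)C(C)(C)C)OC1=O`: 4.26 ug/mL
Compound 2 `COCCCCCCCCCCCCCCC/C=C1/CC(CO)(COC(=O)C(C)(C)C)OC1=O`: < 0.1 ug/mL, a limit of the assay, not a number
Compound 3 `CC(=O)NCCCCCCCCCCCCCCC/C=C1\CC(CO)(COC(=O)C(C)(C)C)OC1=O`: 1.08 ug/mL

In a functional assay on CCRF-CEM cells (Homo sapiens) for antiproliferative activity (on this read-out higher numbers stand for weaker inhibition of growth and lower numbers for stronger inhibition of growth), compound 1 stands highest of the two numbers given, and the nearest measured step is a 3.9-fold lower number from compound 1 to compound 3 (0.60 log units; beyond the scatter), a change only at the far end of the chain. The other measured step, an at least 42-fold lower number from compound 1 to compound 2 (1.62 log units; beyond the scatter), concerns drawn double-bond geometry and does not touch the chain end, so it says nothing about compound 4 `CC(C)(C)C(=O)OCCCCCCCCCCCCCCC/C=C1\CC(CO)(COC(=O)C(C)(C)C)OC1=O`, which differs from compound 1 by (tert-butyl)carbonyl in place of methyl on an oxygen on a saturated carbon. Only the chain-end step offers guidance, and it was modest, so a modest step downward or none beyond the scatter is expected in this assay. Compound 4 is therefore estimated at 2 ug/mL, between 0.6 ug/mL and 7 ug/mL, an expected step of a 2.1-fold lower number from compound 1 to compound 4 (0.33 log units; beyond the scatter).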

Compound 4, concentration for 50% growth inhibition: > 10 ug/mL
Compound 4 gave a limit, no number; the forecaster's own chance of this, stated with the estimate: 5%; middle value at least 5.0-fold (0.69 log units) away from the limit.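

In this assay, the chain end turns out to move the number in both directions: ((tert-butyl)carbonyl)oxy in place of methoxy gives an at least 2.3-fold higher number from compound 1 to compound 4 (0.37 log units; beyond the scatter), whereas acetamido had lowered it. Set against the acetamido end, the same ester gives an at least 9.2-fold higher number from compound 3 to compound 4 (0.96 log units; beyond the scatter). Compound 4 carries a limit of the assay, not a number, so both steps are minimum sizes: the limit of > 10 ug/mL in this assay, at which 1 of the 4 values shown sits.

Still open, from the compounds shown here alone, is whether an amine or a carboxylic acid at the chain end would fall nearer compound 3 or compound 4. Also open, going by these compounds, is whether the ester end would matter as much with the double-bond geometry of compound 2.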